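Aryl substitution in a thiosemicarbazone series: cytotoxicity notes

This account rests on a few compounds, and the source may have more. Where it says the series, first, only, none or still open, it means among the compounds named here.

Compound 1 `CC1=CC[C@@H]([C@@](C)(O)CCCC(C)(C)NC(=S)N/N=C\c2ccccc2)CC1` is the unsubstituted phenyl member of the set. In a functional assay on NCI-H460 cells (Homo sapiens) for cytotoxicity, read by sulforhodamine B assay (a higher number here means that more compound is tolerated, a lower number that less compound is tolerated), compound 1 gives > 100000 nM, which is a limit of the assay and not a number. Compound 2 `CC1=CC[C@@H]([C@@](C)(O)CCCC(C)(C)NC(=S)N/N=C\c2ccc(C)cc2)CC1` carries methyl in place of hydrogen on an aromatic carbon; in this assay compound 2 gives > 100000 nM, again a limit. Compound 3 `CC1=CC[C@@H]([C@@](C)(O)CCCC(C)(C)NC(=S)N/N=C\c2ccccc2[N+](=O)[O-])CC1` carries nitro in place of hydrogen on an aromatic carbon; in this assay compound 3 gives > 100000 nM, also a limit. Accordingly the step that the two limits leave unreadable from compound 1 to compound 2 and the step that the two limits leave unreadable from compound 1 to compound 3 have no readable size, and the same holds for a step that the two limits leave unreadable from compound 2 to compound 3, since every value rests at the limit of > 100000 nM in this assay, at which 3 of the 3 values shown sit.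

Compound 4 `CC1=CC[C@@H]([C@@](C)(O)CCCC(C)(C)NC(=S)N/N=C\c2ccc([N+](=O)[O-])cc2)CC1` differs from compound 1 by nitro in place of hydrogen on an aromatic carbon. The measured steps that bear on it are a step that the two limits leave unreadable from compound 1 to compound 3, the same group entering at another aromatic carbon, and a step that the two limits leave unreadable from compound 1 to compound 2, a different group entering at the same carbon; neither shows a size, and neither shows a direction. For compound 4 the step that the limit leaves unreadable from compound 1 to compound 4 is therefore expected to leave the value at the limit, with no readable change. Compound 4 is estimated at 150000 nM, with a range from 40000 nM to 600000 nM.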

Compound 4, concentration lethal to 50% of the cells: > 100000 nM
Compound 4: only a limit was reported; the forecaster's own chance of this, stated with the estimate: 85%; the middle value is on the limit's open side.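

In this assay compound 4 gives > 100000 nM, a limit of the assay and not a number. No new step to compound 4 from compound 1, compound 2 or compound 3 can be read: the limit of > 100000 nM in this assay, at which 4 of the 4 values shown sit.

The compounds shown leave open whether methyl or nitro on the aromatic ring changes the value in this assay at all, and in which direction.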